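The source may hold more compounds than are shown below. What is called first, only, known or untested is meant among the compounds shown, and "the series" means these compounds.

Working notes on the series. Compound 1 `CSc1ncc(C2C(C(=O)OC3CCCC3)=C(C)NC(C)=C2C(=O)OC2CCCC2)n1Nc1ccccc1` and compound 2 `CSc1ncc(C2C(C(=O)OC3CCCCC3)=C(C)NC(C)=C2C(=O)OC2CCCCC2)n1Nc1ccccc1` carry the shared core with two cycloalkyl esters; in an assay on isolated protein (strain albino) for antagonist activity at Voltage-dependent L-type calcium channel subunit alpha-1C (Cavia porcellus) (on this read-out higher numbers stand for weaker inhibition and lower numbers for stronger inhibition), compound 1 gives 425 nM and compound 2 gives 465 nM, and these two numbers sit within the scatter of one another. Compound 3 `CCOC(=O)C1=C(C)NC(C)=C(C(=O)OCC)C1c1cnc(SC)n1Nc1ccccc1`, with two ethyl esters, gives 1.69 nM in this assay and stands lowest of the three numbers, beyond the scatter from both compound 1 and compound 2.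

Compound 4 `CCOC(=O)C1=C(C)NC(C)=C(C(=O)OCc2ccccc2)C1c1cnc(SC)n1Nc1ccccc1` differs from compound 3 in a single place: phenyl in place of methyl on a saturated chain carbon bound to an oxygen next to a carbonyl group. Among the measured compounds shown here, no measured pair in this set shows exactly this change, so the step can only be judged from the set as a whole. For the measured compounds named here, compound 1 and compound 2 show that both esters enlarged together moves the number far upward from compound 3; here only one ester changes. A smaller upward step is therefore expected, estimated at a 4.7-fold higher number from compound 3 to compound 4 (0.68 log units; beyond the scatter). For compound 4 in this assay a value of about 8 nM is estimated, with a range from 1.5 nM to 40 nM.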

Compound 4, half-maximal inhibitory concentration: 1.86 nM
For compound 4 the middle estimate is 4.3-fold (0.63 log units) above the measured one; the measured number falls inside the stated range.
By their numbers in this assay, from the lowest: compounds 3 and 4 (each within the scatter of the next); then compounds 1 and 2 (each within the scatter of the next).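

Taking ethyl to benzyl at this one ester gives (a 1.1-fold higher number from compound 3 to compound 4 (0.04 log units; within the scatter)) in this assay and so a phenyl on this saturated chain carbon makes no difference that can be told from the scatter. The earlier compounds shown here changed both esters at once and could not show what one ester does alone; this step shows that a large change at a single ester need not move the number. No separate evidence on this result is available to explain it.

Going by these compounds, it remains open whether the second ester accepts benzyl in the same way, and whether two benzyl esters together would keep the number where it stands. Also open, on these data alone, is how this position responds to a longer chain such as butyl, to a carboxylic acid or to an amine on the ester chain.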